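Extending the chain on the oxygen of compound 1

This account rests on a few compounds, and the source may have more. Where it says the series, first, only, none or still open, it means among the compounds named here.

Measured so far:
compound 1 `O=c1ccn([C@@H]2O[C@H](COP(=O)(O)OP(=O)(O)OP(=O)(O)OP(=O)(O)O)[C@@H](O)[C@H]2O)c(=S)[nH]1`: 6830 nM
compound 2 `O=c1[nH]c(=S)ccn1[C@@H]1O[C@H](COP(=O)(O)OP(=O)(O)OP(=O)(O)OP(=O)(O)O)[C@@H](O)[C@H]1O`: 6460 nM

In an in vitro functional assay on 1321-N1 cells for agonist activity at P2Y purinoceptor 6 (Homo sapiens), read by scintillation proximity assay and inositol phosphate accumulation (a higher number here means that more compound is needed for the effect, a lower number that less compound is needed), compound 1 gives 6830 nM, the highest of the two numbers; its nearest neighbour is compound 2, and the step of a 1.1-fold lower number from compound 1 to compound 2 (0.02 log units; within the scatter) lies within the scatter. Compound 3 `O=c1ccn([C@@H]2O[C@H](COP(=O)(O)OP(=O)(O)OP(=O)(O)OP(=O)(O)OP(=O)(O)O)[C@@H](O)[C@H]2O)c(=S)[nH]1` carries a group of 4 heavy atoms (3 oxygen, 1 phosphorus; no ring) in place of a hydrogen atom, on an oxygen, on an oxygen whose other neighbour is phosphorus. Among the measured compounds shown here, no measured step touches this part of the molecule: the one step known, a 1.1-fold lower number from compound 1 to compound 2 (0.02 log units; within the scatter), concerns the aromatic ring instead. With nothing to go on, compound 3 is expected to stay near compound 1, the estimated step being a 1.2-fold lower number from compound 1 to compound 3 (0.09 log units; within the scatter). For compound 3 the estimate in this assay is 5500 nM, within 1500 nM to 18000 nM.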

Compound 3, half-maximal effective concentration: 7330 nM
The estimate for compound 3 lay 1.3-fold (0.12 log units) below the measured number; the range from low to high includes it.
By their numbers in this assay, from the lowest: compounds 2, 1 and 3 (each within the scatter of the next).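

On an oxygen whose other neighbour is phosphorus, a group of 4 heavy atoms (3 oxygen, 1 phosphorus) in place of a hydrogen atom gives a 1.1-fold higher number from compound 1 to compound 3 (0.03 log units; within the scatter) in this assay. Among the compounds shown here, this is the first reading at this position, and it shows that this extension of the chain leaves the number within the scatter. No evidence on hand bears on this result. Going by these compounds, whether an amine or a methyl group on the same oxygen would also stay within the scatter remains open. So does whether the same group would behave alike on compound 2.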